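The source may report more compounds than this note shows. Statements on the series, on what has been measured and on what is new or still open speak of the compounds shown alone.

Working notes on the series. In a functional assay on GBM1 cells (Homo sapiens) for antiproliferative activity, read by WST assay, with a stated time of 72 h (a lower number here means a stronger inhibitor, a higher number a weaker inhibitor), compound 1 `O=C(Nc1cccc(F)c1)Nc1cc2ncncc2cc1OCc1cccc(Cl)c1` gives 3700 nM, while compound 2 `O=C(Nc1ccccc1F)Nc1cc2ncncc2cc1OCc1cccc(F)c1` gives 8000 nM, the higher of the two numbers; the gap between them lies beyond the scatter. Compound 3 `O=C(Nc1ccccc1F)Nc1cc2ncncc2cc1OCc1ccccc1F` is not yet measured. The change from compound 2 is 2-fluorophenyl in place of 3-fluorophenyl on a saturated chain carbon bound to an oxygen on an aromatic ring. Among the compounds with values here, no measured pair shows the effect of moving a fluorine around this ring, so no step beyond the scatter is assumed; the step from compound 2 to compound 3 is expected to be about no change at the digits printed from compound 2 to compound 3 (within the scatter). For compound 3 the expected value in this assay is 8000 nM, estimated to fall between 4000 nM and 16000 nM.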

Compound 3, half-maximal inhibitory concentration: 4200 nM
Beside the measured number, compound 3's estimate is 1.9-fold (0.28 log units) above it; low and high end bracket the measured number.
By their numbers in this assay, from the lowest: compounds 1, 3 and 2 (each within the scatter of the next, the first and the last beyond it).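

In this assay, 2-fluorophenyl in place of 3-fluorophenyl on a saturated chain carbon bound to an oxygen on an aromatic ring gives a 1.9-fold lower number from compound 2 to compound 3 (0.28 log units; within the scatter). Within the data shown here, this is the first one-place step, and it shows that moving the fluorine around this ring produces no step beyond the scatter. No available data bear on the reason for this result. On these data alone, it remains open how an unsubstituted phenyl, a pyridine ring or a longer chain at this place would read in this assay.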